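A Side Chain Exchanged on a Shared Core

The source may hold more compounds than are shown below. What is called first, only, known or untested is meant among the compounds shown, and "the series" means these compounds.

Going by the values given here, three compounds sharing one core have so far been examined in an ADME assay for permeability, using PAMPA (a higher number here means that the compound crosses the layer faster, a lower number that the compound crosses the layer more slowly), and only two of them gave numbers. Compound 1 (`COc1cc(N2CCN(C(=O)N3CCN(C)CC3)CC2)ccc1Nc1nc(NC2CCCCC2)c2nc[nH]c2n1`) gives "impermeable" (no number reported) and so offers no number for comparison. Compound 2 (`COc1cc(N2CCN(CC3CCOC3)CC2)ccc1Nc1nc(NC2CCCCC2)c2nc[nH]c2n1`) gives 1870 10^-6 cm/s in the same measurement. Compound 3 (`COc1cc(N2CCC(C(=O)N3CCOCC3)CC2)ccc1Nc1nc(NC2CCCCC2)c2nc[nH]c2n1`) gives 744 10^-6 cm/s and holds the lower of the two numbers, with compound 2 higher by more than the scatter.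

Compound 4 (`COc1cc(N2CCC(CC(=O)N3CCCC3)CC2)ccc1Nc1nc(NC2CCCCC2)c2nc[nH]c2n1`) has not yet been measured. It differs from compound 3 in one place, on a saturated ring carbon of a six-membered non-aromatic ring with 1 nitrogen, where ((pyrrolidin-1-yl)carbonyl)methyl stands in place of (morpholin-4-yl)carbonyl (((pyrrolidin-1-yl)carbonyl)methyl in place of (morpholin-4-yl)carbonyl on a saturated ring carbon). Among the compounds with values here, no two measured compounds differ in only one place, so no earlier step shows what this exchange does. The expectation therefore rests on a weak guide, the two numbers in hand, with compound 3 at 744 10^-6 cm/s and compound 2 at 1870 10^-6 cm/s. In this assay a small upward change is expected, and a 1.5-fold higher number from compound 3 to compound 4 (0.17 log units; within the scatter) is the estimated step, within the scatter. Compound 4 is estimated at 1100 10^-6 cm/s with an expected range from 450 10^-6 cm/s to 2400 10^-6 cm/s in this measurement.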

Compound 4, apparent permeability: 1690 10^-6 cm/s
Compound 4: middle estimate off by 1.5-fold (0.19 log units), on the low side, within the range that was stated.
By their numbers in this assay, from the lowest: compound 3; then compounds 4 and 2 (each within the scatter of the next).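

In this assay, going by these compounds alone, ((pyrrolidin-1-yl)carbonyl)methyl in place of (morpholin-4-yl)carbonyl on a saturated ring carbon gives a 2.3-fold higher number from compound 3 to compound 4 (0.36 log units; beyond the scatter) and is the first exchange here confined to one place. It shows that the group at this position can move the read-out by more than the scatter, even though the leaving and entering groups have the same count of heavy atoms. The exchange alters several things together, from a six-membered ring with 2 hetero atoms to a five-membered ring with 1 hetero atom and from 2 hydrogen-bond acceptors to 1, and no measurement shown explains the step or ties it to any one of these differences.

Still open, going by these compounds, is whether ((morpholin-4-yl)carbonyl)methyl or (pyrrolidin-1-yl)carbonyl, each of which would separate the ring from the chain, would stand nearer to compound 3 or to compound 4. Also open, on these data alone, is how a longer chain before the carbonyl, or a simple amine in place of the amide, would read at this ring carbon.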